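This account rests on a few compounds, and the source may have more. Where it says the series, first, only, none or still open, it means among the compounds named here.

Compound 1 , whose structure is `COc1cc(C)cc(-c2nn(CC#N)cc2-c2ccnc(-c3ccc(N(C)C)cc3)c2)c1`, was tested in a functional assay on SNB-19 cells (Homo sapiens) for inhibition, read by sulforhodamine B assay, with a stated time of 48 h; on this read-out higher numbers stand for weaker inhibition of growth and lower numbers for stronger inhibition of growth. In this assay compound 1 gives only a limit of the assay, > 100000 nM, and not a measured number. A second compound, compound 2 with the structure `COc1cc(C)cc(-c2nn(CC#N)cc2-c2ccc(-c3cccc(C(C)=O)c3)nc2)c1`, was tested alongside it. In this assay compound 2 likewise returns only a limit, > 100000 nM. Both values shown rest at the limit of > 100000 nM in this assay, at which 2 of the 2 values shown sit, so compound 1 stands neither above nor below anything measured here. The next compound, compound 3 with the structure `Cc1cc(O)cc(-c2nn(CC#N)cc2-c2ccnc(-c3ccc(N(C)C)cc3)c2)c1`, differs from compound 1 in one place: hydrogen in place of methyl on an oxygen on an aromatic ring, that is 3-methoxy-5-methylphenyl becoming 3-hydroxy-5-methylphenyl. Among the measured compounds shown here, no step between measured compounds exists to gauge such a change, so the expected step of a number no higher from compound 1 to compound 3 (the limit leaves the size open) is none beyond the scatter, with compound 3 expected to give only a limit as well. The estimate for compound 3 is 100000 nM, ranging from 30000 nM to 300000 nM.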

Compound 3, concentration for total growth inhibition: 43900 nM
Compound 3: middle estimate off by 2.3-fold (0.36 log units), on the high side; the measured number falls inside the stated range.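

In this assay, swapping methoxy for hydroxy on the aryl ring, so that 3-methoxy-5-methylphenyl becomes 3-hydroxy-5-methylphenyl, gives an at least 2.2-fold lower number from compound 1 to compound 3 (0.35 log units; beyond the scatter). Compound 3 is thus the first compound shown with a measured number rather than a limit, and this shows that a change at this one oxygen can strengthen growth inhibition on this read-out. The full size of the step stays unknown because its starting point is only a limit: the limit of > 100000 nM in this assay, at which 2 of the 3 values shown sit.

The compounds shown do not tell how an amine in place of the hydroxy, or a longer chain such as ethoxy, would compare with compound 3. They also leave open whether the same swap would lower the number on the different core of compound 2.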